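Salicylanilide series: cytotoxicity step toward the carbamoyl analogue

This account rests on a few compounds, and the source may have more. Where it says the series, first, only, none or still open, it means among the compounds named here.

Measured so far:
Compound 1 `O=C(Nc1ccc(F)cc1)c1cc(Cl)ccc1O` — 17000 nM
Compound 2 `COc1ccc(NC(=O)c2cc(Cl)ccc2O)cc1` — > 60000 nM

In an ADME assay on cells (Macrophage, Mus musculus) for cytotoxicity, read by resazurin assay, with a stated time of 3 days (on this read-out higher numbers stand for weaker inhibition and lower numbers for stronger inhibition), compound 1 gives 17000 nM as a number. For compound 2 the result is a limit of the assay, > 60000 nM, not a number; it sits at the limit of > 60000 nM in this assay, at which 1 of the 2 values shown sits. The step of an at least 3.5-fold higher number from compound 1 to compound 2 (0.54 log units; beyond the scatter) is therefore known only as a bound. Compound 2 thus stands at the top of the numbers shown, with no figure of its own.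

Compound 3 `NC(=O)c1ccc(NC(=O)c2cc(Cl)ccc2O)cc1` is not yet measured. It differs from compound 2 by carbamoyl in place of methoxy on an aromatic carbon: the ring carries the new group para to a large group. Among the measured compounds shown here, the only measured step, an at least 3.5-fold higher number from compound 1 to compound 2 (0.54 log units; beyond the scatter), bears on this change merely by showing that replacing fluoro at this carbon already carried the number past the limit. For compound 3 no step beyond the scatter is expected, a number no higher from compound 2 to compound 3 (the limit leaves the size open), with the value likely again a limit. The estimate for compound 3 in this assay is 60000 nM, with a range from 25000 nM to 120000 nM.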

Compound 3, half-maximal inhibitory concentration: > 60000 nM
Compound 3: a limit, no number (the forecaster's own chance of this, stated with the estimate: 70%); the middle value sits exactly at the limit.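

In this assay compound 3 returns a limit and not a number, > 60000 nM. A second group at this aromatic carbon, here carbamoyl with its hydrogen-bond donor, gives an at least 3.5-fold higher number from compound 1 to compound 3 (0.54 log units; beyond the scatter), so the move away from fluoro to a higher reading is no longer tied to methoxy alone. Carbamoyl in place of methoxy gives a step that cannot be read, and the series now gathers at a single limit: the limit of > 60000 nM in this assay, at which 2 of the 3 values shown sit.

The compounds shown leave open how far compound 2 and compound 3 lie past that limit, and whether the two differ at all. As far as these compounds go, it also remains open whether an amine or a carboxylic acid on the same carbon would return a number in this assay or another limit.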